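A few compounds are considered here, and "the series" means these few. Any claim that something is new, unique, unknown or untested is made for them only; others in the source may bear on it.

Measured in a physicochemical assay for lipophilicity, read by HPLC, at pH 7.5; a lower number here means a more polar compound, a higher number a more lipophilic compound:
Compound 1 `CC[C@@H](Nc1c(C#N)c(-c2ccc(-c3ccc(OC)cc3)cc2)nc2cnccc12)C(N)=O`: 2.7
Compound 2 `CC[C@@H](Nc1c(C#N)c(-c2ccc(-c3cnccc3C)cc2)nc2cnccc12)C(N)=O`: 2

Within the data shown here, of these two compounds, compound 2 stands lower in this assay at 2, with compound 1 as its only neighbour. Compound 3 `CC[C@@H](Nc1c(C#N)c(-c2ccc(-c3cccnc3C)cc2)nc2cnccc12)C(N)=O` has not yet been measured. It differs from compound 2 in one place: 2-methylpyridin-3-yl in place of 4-methylpyridin-3-yl on an aromatic carbon. The two have the same atoms, joined differently.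

Among the measured compounds shown here, only one measured step bears on this change, and only indirectly. This is a number 0.70 log units lower from compound 1 to compound 2 (beyond the scatter), where 4-methylpyridin-3-yl took the place of 4-methoxyphenyl. That step exchanged one group for a different kind of group, whereas the groups now exchanged count the same. For the measured compounds named here, no measured pair shows what this particular rearrangement does, so no step beyond the scatter is expected in this assay. The estimate is a number 0.10 log units higher from compound 2 to compound 3 (within the scatter). For compound 3 the expected value is 2.1, with an estimated range of 1.7 to 2.5.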

Compound 3, distribution coefficient: 1.9
Compound 3: middle estimate off by 0.20 log units, on the high side; measured number inside the range.
By their numbers in this assay, from the lowest: compounds 3 and 2 (each within the scatter of the next); then compound 1.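

In this assay, exchanging 4-methylpyridin-3-yl for 2-methylpyridin-3-yl on this aromatic carbon, para to a large group, gives a number 0.10 log units lower from compound 2 to compound 3 (within the scatter), so here this rearrangement of the same atoms does not separate the two compounds. The step away from 4-methoxyphenyl is now seen with a second methylpyridinyl group, with a number 0.80 log units lower from compound 1 to compound 3 (beyond the scatter). No measurement offered here accounts for either step.

The compounds shown leave open whether a pyridine ring with an amine or a longer chain in place of the methyl group would stay level with compound 2 and compound 3 in this assay. They also leave open whether the same exchange of the two methylpyridinyl groups would stay within the scatter on a different core.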